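Working notes: changing the piperazine side chain

The source may hold more compounds than are shown below. What is called first, only, known or untested is meant among the compounds shown, and "the series" means these compounds.

In a functional assay on MCF7 cells (Homo sapiens) for cytotoxicity, read by MTT assay, with a stated time of 72 h (a lower number here means a stronger inhibitor, a higher number a weaker inhibitor), compound 2 `CCCCN1CCN(CCCCn2c3c(c4ccccc42)C(=O)c2c[n+]([O-])c4ccccc4c2C3=O)CC1` gives 6900 nM as the highest of the three measured numbers, against compound 1 `O=C1c2c[n+]([O-])c3ccccc3c2C(=O)c2c1c1ccccc1n2Cc1cn(CC(O)CO)nn1` at 1110 nM and compound 3 `O=C1c2c[n+]([O-])c3ccccc3c2C(=O)c2c1c1ccccc1n2Cc1cn([C@H]2C[C@H](O)[C@@H](CO)O2)nn1` at 530 nM in the same read-out.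

Compound 4 `CN1CCN(CCCCCn2c3c(c4ccccc42)C(=O)c2c[n+]([O-])c4ccccc4c2C3=O)CC1` has not been measured. The change from compound 2 ((4-methylpiperazin-1-yl)methyl in place of 4-butylpiperazin-1-yl on a saturated chain carbon, four bonds along the chain from an aromatic nitrogen) puts (4-methylpiperazin-1-yl)methyl in place of 4-butylpiperazin-1-yl on a saturated chain carbon, four bonds along the chain from an aromatic nitrogen.

Among the compounds with values here, no measured pair varies this side chain. Within the data shown here, the only measured step in one place is modest (a 2.1-fold lower number from compound 1 to compound 3 (0.32 log units; beyond the scatter)) and lies in a different side chain, so it serves only as a rough guide to size. A small step, slightly downward if anything, is therefore expected. The estimated step (a 1.4-fold lower number from compound 2 to compound 4 (0.14 log units; within the scatter)) is expected to stay within the scatter. In this assay compound 4 is expected at 5000 nM with a range from 1800 nM up to 14000 nM on this estimate.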

Compound 4, half-maximal inhibitory concentration: 1260 nM
The estimate for compound 4 lay 4.0-fold (0.60 log units) above the measured number; measured number below the stated range.
By their numbers in this assay, from the lowest: compound 3; then compounds 1 and 4 (each within the scatter of the next); then compound 2.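

In this assay the side chain on the aromatic nitrogen of this series is now seen to respond within the piperazine type itself: (4-methylpiperazin-1-yl)methyl in place of 4-butylpiperazin-1-yl on a saturated chain carbon, four bonds along the chain from an aromatic nitrogen, gives a 5.5-fold lower number from compound 2 to compound 4 (0.74 log units; beyond the scatter). A piperazine side chain is also compatible with a number matching that of a side chain carrying a triazole and a diol, as a 1.1-fold higher number from compound 1 to compound 4 (0.06 log units; within the scatter) shows. The data shown offer no explanation for either step.

Going by these compounds, the step from compound 2 to compound 4 alters the alkyl group on the piperazine and the length of the chain together, and the share of each remains open. Also open, on these data alone, is how a morpholine ring or an unsubstituted piperazine with a free secondary amine would read on the same chain.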